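The source may report more compounds than this note shows. Statements on the series, on what has been measured and on what is new or still open speak of the compounds shown alone.

Measured compounds:
Compound 1, `CC(C)NCCS(=O)(=O)NC(=O)c1ccc(Nc2nc(NC3(c4ccc(Cl)cc4)CC3)nc(OCC(F)(F)F)n2)cc1`: 45 nm/s
Compound 2, `CCS(=O)(=O)NC(=O)c1ccc(Nc2nc(NC3(c4ccc(Cl)cc4)CC3)nc(OCC(F)(F)F)n2)cc1`: 28 nm/s
Compound 3, `O=C(NS(=O)(=O)c1ccccc1)c1ccc(Nc2nc(NC3(c4ccc(Cl)cc4)CC3)nc(OCC(F)(F)F)n2)cc1`: 182 nm/s

In a physicochemical assay for permeability, using PAMPA, at pH 7.4 (a lower number here means that the compound crosses the layer more slowly, a higher number that the compound crosses the layer faster), compound 3 gives the highest of the three numbers; its nearest neighbour is compound 1, the step of a 4.0-fold higher number from compound 1 to compound 3 (0.61 log units; beyond the scatter) being beyond the scatter, and the furthest is compound 2, with a 6.5-fold higher number from compound 2 to compound 3 (0.81 log units; beyond the scatter) also beyond the scatter. The step of a 1.6-fold lower number from compound 1 to compound 2 (0.21 log units; within the scatter) lies within the scatter.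

Compound 4, `O=C(NS(=O)(=O)CCNCc1ccccc1)c1ccc(Nc2nc(NC3(c4ccc(Cl)cc4)CC3)nc(OCC(F)(F)F)n2)cc1`, has not yet been measured. It differs from compound 3 in one place: 2-(benzylamino)ethyl in place of phenyl on a sulfonyl sulfur. The step that bears most directly on this change is a 4.0-fold higher number from compound 1 to compound 3 (0.61 log units; beyond the scatter) read in reverse, since compound 1 carries 2-(isopropylamino)ethyl on the sulfonyl sulfur and compound 4 carries 2-(benzylamino)ethyl there, both in place of the phenyl of compound 3. The step of a 6.5-fold higher number from compound 2 to compound 3 (0.81 log units; beyond the scatter) points the same way. A step of about that size, downward, is therefore expected in this assay for compound 4, with some allowance for the benzyl group being untested here.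

The estimate for compound 4 in this assay is 55 nm/s, within a range of 25 nm/s to 120 nm/s, which means an expected step of a 3.3-fold lower number from compound 3 to compound 4 (0.52 log units; beyond the scatter).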

Compound 4, apparent permeability: 49 nm/s
Compound 4: the middle estimate sits 1.1-fold (0.05 log units) above what was measured; low and high end bracket the measured number.
By their numbers in this assay, from the lowest: compounds 2, 1 and 4 (each within the scatter of the next); then compound 3.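

In this assay the step (a 3.7-fold lower number from compound 3 to compound 4 (0.57 log units; beyond the scatter)) shows that the six-membered aromatic ring alone does not carry the higher number of compound 3: 2-(benzylamino)ethyl also holds such a ring, yet compound 4 sits with the compounds that have a saturated chain on the sulfonyl sulfur. The group on the amine nitrogen makes no readable difference here, since benzyl in place of isopropyl gives only a step within the scatter (a 1.1-fold higher number from compound 1 to compound 4 (0.04 log units; within the scatter)), and the step from the plain ethyl compound (a 1.8-fold higher number from compound 2 to compound 4 (0.24 log units; within the scatter)) also stays within the scatter. No measurement among those shown gives a reason for these numbers.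

The compounds shown leave open whether a 2-phenylethyl chain, which has the ring and the chain but no amine nitrogen, would read like compound 3 or like compound 4. They also leave open whether a pyridine ring or a substituted phenyl on the sulfonyl sulfur would hold the number of compound 3, and whether a chain ending in a carboxylic acid would fall with the saturated chains.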